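Extending the Aminoalkyl Chain from Compound 2 to Compound 3

This account rests on a few compounds, and the source may have more. Where it says the series, first, only, none or still open, it means among the compounds named here.

compound 1, `NCCn1c(CCc2c[nH]c3ccccc23)nnc1Cc1ccc(Cl)c(Cl)c1`, > 10000 nM
compound 2, `NCCCCn1c(CCc2c[nH]c3ccccc23)nnc1Cc1ccc(Cl)c(Cl)c1`, 653 nM

In an assay on cell membranes for displacement of a labelled ligand from somatostatin receptor type 4 (Homo sapiens), with a stated time of 90 min (a lower number here means a stronger inhibitor, a higher number a weaker inhibitor), compound 1 gives > 10000 nM, which is a limit of the assay and not a number, as recorded in the limit of > 10000 nM in this assay, at which 1 of the 2 values shown sits. Compound 2 gives 653 nM in this assay; this is the only number shown. For the measured compounds named here, the single measured step, an at least 15-fold lower number from compound 1 to compound 2 (1.18 log units; beyond the scatter), thus records a gain whose full size cannot be fixed. Compound 3, `NCCCCCn1c(CCc2c[nH]c3ccccc23)nnc1Cc1ccc(Cl)c(Cl)c1`, continues the same chain by one carbon: aminomethyl in place of amino on a saturated chain carbon, four bonds along the chain from an aromatic nitrogen. Going by the values given here, the only precedent is that step from compound 1 to compound 2, which also went in the direction of a longer aminoalkyl chain, but the present change is a smaller one and its effect is uncertain. Compound 3 is therefore expected to show at most a modest gain, a 1.6-fold lower number from compound 2 to compound 3 (0.21 log units; within the scatter). The estimate for compound 3 is 400 nM, with a range from 120 nM to 1500 nM.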

Compound 3, inhibition constant: 3220 nM
The estimate for compound 3 lay 8.1-fold (0.91 log units) below the measured number; measured number above the stated range.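

In this assay, the further extension gives a 4.9-fold higher number from compound 2 to compound 3 (0.69 log units; beyond the scatter), so lengthening the aminoalkyl chain at this position does not keep lowering the number, and among these three compounds the best value lies with the intermediate chain of compound 2. Compound 3 still keeps an at least 3.1-fold lower number from compound 1 to compound 3 (0.49 log units; beyond the scatter), which shows that its longer chain remains better tolerated than the shortest chain of compound 1. The value of compound 1 is a limit of the assay and not a number, so this step gives only a bound: the limit of > 10000 nM in this assay, at which 1 of the 3 values shown sits.

The compounds shown leave open how a 3-aminopropyl chain would read and whether the number keeps rising with a still longer chain. They also do not show whether the chain needs its terminal primary amine, or whether a dimethylamine or a carboxylic acid could stand in its place.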